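This account rests on a few compounds, and the source may have more. Where it says the series, first, only, none or still open, it means among the compounds named here.

In a functional assay on DU-145 cells (Homo sapiens) for cytotoxicity, read by trypan blue exclusion, with a stated time of 96 h (a lower number here means a stronger inhibitor, a higher number a weaker inhibitor), three compounds with a shared core have been measured. Compound 1 `COC(=O)CCNc1cc(CS(=O)(=O)/C=C/c2c(OC)cc(OC)cc2OC)ccc1OC` gives 1500 nM, compound 2 `COC(=O)C(F)(F)Nc1cc(CS(=O)(=O)/C=C/c2c(OC)cc(OC)cc2OC)ccc1OC` gives 250 nM, and compound 3 `COC(=O)C(Nc1cc(CS(=O)(=O)/C=C/c2c(OC)cc(OC)cc2OC)ccc1OC)c1ccccc1` gives 75 nM, the lowest number of the three. Compound 4 `COC(=O)C(Nc1cc(CS(=O)(=O)/C=C/c2c(OC)cc(OC)cc2OC)ccc1OC)c1ccc(F)cc1` differs from compound 3 by fluoro in place of hydrogen on an aromatic carbon, turning phenyl into 4-fluorophenyl: fluoro in place of hydrogen on an aromatic carbon. For the measured compounds named here, no measured step tests this exact change. The nearest evidence comes from wider swaps of the group on the nitrogen: a 6.0-fold lower number from compound 1 to compound 2 (0.78 log units; beyond the scatter), a 20-fold lower number from compound 1 to compound 3 (1.30 log units; beyond the scatter) and a 3.3-fold lower number from compound 2 to compound 3 (0.52 log units; beyond the scatter). A single fluoro is a much smaller edit, so no step beyond the scatter is expected, in either direction. The expected result is a 1.1-fold lower number from compound 3 to compound 4 (0.03 log units; within the scatter). Compound 4 is estimated at 70 nM, within a range of 30 nM to 170 nM.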

Compound 4, half-maximal inhibitory concentration: 300 nM
Compound 4: middle estimate off by 4.3-fold (0.63 log units), on the low side; measured number above the stated range.
By their numbers in this assay, from the lowest: compound 3; then compounds 2 and 4 (each within the scatter of the next); then compound 1.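

In this assay a single fluoro on the phenyl ring is no silent edit: it gives a 4.0-fold higher number from compound 3 to compound 4 (0.60 log units; beyond the scatter) and shows that this spot, para to a large group, responds to one added atom. The edge held by compound 3 is lost, with a 1.2-fold higher number from compound 2 to compound 4 (0.08 log units; within the scatter) placing compound 4 level with compound 2, while a 5.0-fold lower number from compound 1 to compound 4 (0.70 log units; beyond the scatter) still stands. Nothing shown gives a measured reason for this change.

The compounds shown leave open whether the loss is particular to fluoro or follows any group at this spot, such as chloro, methoxy or hydroxyl.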